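A few compounds are considered here, and "the series" means these few. Any claim that something is new, unique, unknown or untested is made for them only; others in the source may bear on it.

Working notes on a small series sharing one core, followed in an ADME assay on microsomes from liver (Rattus norvegicus, strain Wistar) for metabolic stability, tested at 2.5 uM; on this read-out higher numbers stand for fast clearance and lower numbers for slow clearance.

Compound 1, `Brc1cccc2c1nnn2Cc1ccccc1`, is the parent of the set; in this assay compound 1 gives 2 mL/min/g. Compound 2, `Fc1ccc(Cn2nnc3c(Br)cccc32)cc1`, differs from compound 1 by fluoro in place of hydrogen on an aromatic carbon. In this assay compound 2 gives 1 mL/min/g, and the step is a 2.0-fold lower number from compound 1 to compound 2 (0.30 log units; within the scatter). Compound 3, `Clc1ccc(Cn2nnc3c(Br)cccc32)cc1`, differs from compound 1 by chloro in place of hydrogen on an aromatic carbon; in this assay compound 3 gives 2.2 mL/min/g, which is a 1.1-fold higher number from compound 1 to compound 3 (0.04 log units; within the scatter). Between compound 2 and compound 3 the step is a 2.2-fold higher number from compound 2 to compound 3 (0.34 log units; beyond the scatter), so compound 3 holds the highest number of the three, but its gap to compound 1 is within the scatter.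

Compound 4, `Fc1cc(Cl)ccc1Cn1nnc2c(Br)cccc21`, awaits measurement. It differs from compound 3 by fluoro in place of hydrogen on an aromatic carbon. The same kind of change was made from compound 1 to compound 2, namely (fluoro in place of hydrogen on an aromatic carbon), and there it gave a 2.0-fold lower number from compound 1 to compound 2 (0.30 log units; within the scatter). The surroundings are not identical: in compound 2 the entering fluoro stands para to a large group, whereas in compound 4 it stands ortho to a large group and meta to a chloro group, the chloro group being the difference between the two cores, (chloro in place of hydrogen on an aromatic carbon). The expectation for compound 4 rests on compound 3 with 2.2 mL/min/g and on the earlier step of a 2.0-fold lower number from compound 1 to compound 2 (0.30 log units; within the scatter). The expected step is a 1.7-fold lower number from compound 3 to compound 4 (0.23 log units; within the scatter), set beside the measured 2.0-fold lower number from compound 1 to compound 2 (0.30 log units; within the scatter). Compound 4 is estimated at 1.3 mL/min/g, with a likely range from 0.6 mL/min/g to 2.8 mL/min/g.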

Compound 4, intrinsic clearance in a liver preparation (reported as CLH), per the amount of preparation that the assay uses: 3.8 mL/min/g
Compound 4: the middle estimate sits 2.9-fold (0.47 log units) below what was measured; measured number above the stated range.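

In this assay, fluoro in place of hydrogen on an aromatic carbon gives a 1.7-fold higher number from compound 3 to compound 4 (0.24 log units; within the scatter), and on its own this step stays within the scatter. Set beside the earlier use of the same change on the core of compound 1, however, the change does not carry over as one fixed step to the chloro-bearing core of compound 3: the same change on two cores in this assay, a 2.0-fold lower number (0.30 log units; within the scatter) from compound 1 to compound 2 and a 1.7-fold higher number (0.24 log units; within the scatter) from compound 3 to compound 4, 3.5-fold (0.54 log units) apart, beyond the scatter of two such steps

This shows that a step read on one core of this series is a poor guide to the same change on the other, although only the gap between the two steps, and neither step alone, lies beyond the scatter. It does not show what sets the two steps apart, since the entering fluoro in compound 4 stands ortho to a large group and meta to a chloro group, so that compound 2 and compound 4 differ in the place of the fluoro as well as in the chloro group.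

Still open, on these data alone, is how fluoro at the place it holds in compound 4 behaves on the core of compound 1, without the chloro group. Also open, as far as these compounds go, is whether a methoxy group or an amine at that place would follow either step.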